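The compounds below may be only part of what the source reports. "The series", "measured", "known", "first", "only" and "open" are said of these compounds alone.

Measured in a physicochemical assay for solubility, read by nephelometry, measured as kinetic solubility, at pH 6.5; a higher number here means a more soluble compound, a lower number a less soluble compound:
- compound 1 `NCc1csc(NC(=O)c2ccon2)n1`: 50 ug/mL
- compound 2 `CC(C)(C)c1cc(C(=O)Nc2nc(CNS(C)(=O)=O)cs2)n(Cc2ccccc2)n1`: 3.1 ug/mL
- compound 3 `NCc1csc(NC(=O)c2ccn[nH]2)n1`: > 100 ug/mL

The value for compound 3 is a limit of the assay, not a number. Of the two plain numbers in this assay, the lower belongs to compound 2 at 3.1 ug/mL. Compound 1 gives 50 ug/mL. The gap between these two compounds lies beyond the scatter.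

Compound 4 `Cc1csc(NC(=O)c2cc(C(C)(C)C)nn2Cc2ccccc2)n1` differs from compound 2 as follows: hydrogen in place of methanesulfonamido on a saturated chain carbon bound to an aromatic carbon. Within the data shown here, the only measured step, an at least 2.0-fold higher number from compound 1 to compound 3 (0.30 log units; that floor lies within the scatter), concerns a different change, 1H-pyrazol-5-yl in place of 1,2-oxazol-3-yl on a carbonyl carbon, so it gives no size for this one. With only compound 2 at 3.1 ug/mL to go on, no shift beyond the scatter is expected. The estimated step is a 1.6-fold lower number from compound 2 to compound 4 (0.19 log units; within the scatter). For compound 4 the expected value is 2 ug/mL, within an estimated range of 0.5 ug/mL to 6 ug/mL.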

Compound 4, solubility: < 1.6 ug/mL
Compound 4: a limit, no number; the forecaster's own chance of this, stated with the estimate: 15%; middle value at least 1.2-fold (0.09 log units) away from the limit.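

In this assay, among these compounds, replacing methanesulfonamido with hydrogen on a saturated chain carbon bound to an aromatic carbon gives the first reading for this position: an at least 1.9-fold lower number from compound 2 to compound 4 (0.28 log units; that floor lies within the scatter). The earlier step concerned a different place, so it gave no size for this change. Compound 4 stands at a limit of the assay, not a number, so only a floor is known for this step: the limit of < 1.6 ug/mL in this assay, at which 1 of the 4 values shown sits.

As far as these compounds go, the full size of the step remains open. So does how a carboxylic acid or a hydroxyl group on that same carbon would read in this assay.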